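A few compounds are considered here, and "the series" means these few. Any claim that something is new, unique, unknown or untested is made for them only; others in the source may bear on it.

Compound 1 `Cc1cc(NCc2cccnc2)n2nc(C)c(-c3ccccc3)c2n1`: 110000 nM
Compound 2 `Cc1cc(NCc2ccccn2)n2ncc(-c3ccc(C(F)(F)F)cc3)c2n1`: < 5000 nM
Compound 3 `Cc1cc(NCc2ccccn2)n2ncc(-c3ccc(C#N)cc3)c2n1`: < 5000 nM

In a physicochemical assay for solubility, read by HPLC, using the shake flask method, measured as kinetic solubility, with a stated time of 2 h, at pH 7.4 (on this read-out higher numbers stand for higher solubility and lower numbers for lower solubility), compound 1 gives 110000 nM. For compound 2 the value < 5000 nM is a limit of the assay, not a number. For compound 3 the value < 5000 nM is likewise a limit. Compound 3 therefore sits at the limit of < 5000 nM in this assay, at which 2 of the 3 values shown sit, and a step that the two limits leave unreadable from compound 2 to compound 3 cannot be read. Compound 4 `Cc1cc(NCc2ccccn2)n2ncc(-c3ccn(C)n3)c2n1` differs from compound 3 in one place: 1-methyl-1H-pyrazol-3-yl in place of 4-cyanophenyl on an aromatic carbon. No measured step covers this change; the single step shown concerns a different group and is itself unreadable. With compound 3 at a limit, little constrains compound 4. The step of an at least 3.0-fold higher number from compound 3 to compound 4 (0.47 log units; beyond the scatter) is expected to run upward, though its size is uncertain. Compound 4 is estimated at 15000 nM, between 3000 nM and 80000 nM.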

Compound 4, solubility: 188000 nM
Estimate against measurement, compound 4: 13-fold (1.10 log units) below, and the stated range ends below it.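

Among the compounds shown here, on this aromatic carbon, 1-methyl-1H-pyrazol-3-yl in place of 4-cyanophenyl gives the only readable step so far in this assay: an at least 37-fold higher number from compound 3 to compound 4 (1.57 log units; beyond the scatter). The position therefore tolerates a large change in this read-out, whereas the step from trifluoromethyl to cyano on the phenyl ring cannot be read. The value of compound 3 is a limit of the assay, not a number: the limit of < 5000 nM in this assay, at which 2 of the 4 values shown sit. This single exchange does not separate the effect of losing the nitrile from that of bringing in the five-membered ring. From the compounds shown here alone, whether a pyridine, an unmethylated pyrazole or an amine on this carbon would read alike remains open.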